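Trimming a Piperidine Side Group in a Cytotoxicity Series

The source may report more compounds than this note shows. Statements on the series, on what has been measured and on what is new or still open speak of the compounds shown alone.

Measured compounds:
- compound 1, `Cc1ncc([N+](=O)[O-])n1CCSC(=S)N1CCC(OC(=O)CN2CCCCC2)CC1`: 760 ug/mL
- compound 2, `CCC1CCCCN1C(=S)SCCn1c([N+](=O)[O-])cnc1C`: 94 ug/mL
- compound 3, `Cc1ncc([N+](=O)[O-])n1CCSC(=S)N1CCC2(CC1)OCCO2`: > 1000 ug/mL

Of the compounds shown here, three share one core and have been tested in an ADME assay on HeLa cells (Homo sapiens) for cytotoxicity; on this read-out lower numbers stand for stronger inhibition and higher numbers for weaker inhibition. Compound 1 gives 760 ug/mL, the highest of the two numbers recorded, and compound 2 sits well away from it at 94 ug/mL, a gap beyond the scatter. Compound 3 gives > 1000 ug/mL, which is a limit of this assay rather than a number; the record notes that (the limit of > 1000 ug/mL in this assay, at which 1 of the 3 values shown sits).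

The next compound, compound 4, `Cc1ncc([N+](=O)[O-])n1CCSC(=S)N1CCC(C)CC1`, has not yet been measured. It differs from compound 1 at one place: methyl in place of (((piperidin-1-yl)methyl)carbonyl)oxy on a saturated ring carbon. Compound 4 therefore carries a far smaller side group than compound 1, and in that sense resembles compound 2, whose value of 94 ug/mL is the lower number recorded.

The step from compound 1 to compound 4 is expected to be a 3.8-fold lower number from compound 1 to compound 4 (0.58 log units; beyond the scatter), a downward move beyond the scatter. Compound 4 is estimated at 200 ug/mL, with a plausible range from 60 ug/mL to 700 ug/mL.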

Compound 4, half-maximal inhibitory concentration: 190 ug/mL
The estimate for compound 4 lay 1.1-fold (0.02 log units) above the measured number, within the range that was stated.
By their numbers in this assay, from the lowest: compound 2; then compound 4; then compound 1. At a limit, above all of these: compound 3.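

Replacing (((piperidin-1-yl)methyl)carbonyl)oxy with methyl on this saturated ring carbon gives a 4.0-fold lower number from compound 1 to compound 4 (0.60 log units; beyond the scatter) in this assay. Going by these compounds alone, this is the first pair in the set that differs in only one place, so it is the first direct sign that the group at this position can shift the read-out, and here the much smaller group gives the stronger inhibition. None of the available measurements explains this shift.

The whole side group leaves in a single step, so it remains unclear whether its piperidine ring, its carbonyl or its overall size accounts for the difference. From the compounds shown here alone, it is also open whether a hydroxyl group, a simple amine or a longer alkyl chain on the same carbon would give a number closer to that of compound 4 or to that of compound 1.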